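The compounds below may be only part of what the source reports. "The series", "measured", "known", "first", "only" and "open" are said of these compounds alone.

Compound 1 `CC(=O)N1N=C(c2ccc3ccccc3c2)OC1c1ccccc1F` gives 6.05 ug/mL
Compound 2 `CC(=O)N1N=C(c2ccc3ccccc3c2)OC1c1ccccc1[N+](=O)[O-]` gives 9.01 ug/mL

In a functional assay on B16-F10 cells (Mus musculus) for antiproliferative activity, read by MTT assay, with a stated time of 48 h (on this read-out higher numbers stand for weaker inhibition and lower numbers for stronger inhibition), compound 2 gives 9.01 ug/mL and has only compound 1 as a neighbour. The two lie within the scatter of each other, so neither can be ranked.

The change leading to compound 3 `CC(=O)N1N=C(c2ccc3ccccc3c2)OC1c1ccncc1` is pyridin-4-yl in place of 2-nitrophenyl on a saturated ring carbon and, in short, puts pyridin-4-yl in place of 2-nitrophenyl on a saturated ring carbon. Going by the values given here, one measured step bears on this, and only in part. It is a 1.5-fold higher number from compound 1 to compound 2 (0.17 log units; within the scatter) and it swaps nitro for fluoro on an aromatic carbon, whereas here the whole aromatic ring is exchanged. Among the compounds with values here, no measured compound has a hetero atom in that ring, so the data give no direction. A step beyond the scatter is therefore not expected in this assay in either direction, although the range must stay wide with so little to go on. The expected size is a 1.1-fold lower number from compound 2 to compound 3 (0.05 log units; within the scatter) by estimate. Compound 3 is thus estimated to give 8 ug/mL in a range from 3.5 ug/mL to 18 ug/mL in this read-out.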

Compound 3, half-maximal inhibitory concentration: 2.97 ug/mL
Beside the measured number, compound 3's estimate is 2.7-fold (0.43 log units) above it; the measured number lies below the stated range.
By their numbers in this assay, from the lowest: compound 3; then compounds 1 and 2 (each within the scatter of the next).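

The step of a 3.0-fold lower number from compound 2 to compound 3 (0.48 log units; beyond the scatter) and the step of a 2.0-fold lower number from compound 1 to compound 3 (0.31 log units; beyond the scatter) both lie beyond the scatter in this assay. Going by these compounds alone, the earlier swap on the aromatic ring, nitro for fluoro, gave only a 1.5-fold higher number from compound 1 to compound 2 (0.17 log units; within the scatter) and could not be ranked, so this is the first sign that the saturated ring carbon responds to what it carries, and that exchanging the whole ring can shift the number towards stronger inhibition. Among these three compounds, the one whose ring holds a hetero atom gives the lowest number, but nothing measured here explains why pyridin-4-yl does better than either substituted phenyl group.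

The compounds shown leave open whether the gain comes from the ring nitrogen itself or simply from losing the fluoro or nitro group, and an unsubstituted phenyl group at this carbon would separate those two readings. On these data alone, how far the position tolerates other kinds of group also stays unknown, for example a phenyl ring carrying an amine or a carboxylic acid, or a longer chain in place of the ring.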